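A New Amine Group on the Ring Carbon

A few compounds are considered here, and "the series" means these few. Any claim that something is new, unique, unknown or untested is made for them only; others in the source may bear on it.

Three compounds have been measured so far in a functional assay on CHO cells for activation of 5-hydroxytryptamine receptor 1D (Homo sapiens), read by GTPgammaS binding; a higher number here means a larger maximal response, a lower number a smaller maximal response:

Compound 1 `O=S(=O)(NCC1CCN(CCCc2c[nH]c3ccc(-n4cnnc4)cc23)CC1)c1ccccc1` gives 73%.
Compound 2 `CN(Cc1cccs1)C1CCN(CCCc2c[nH]c3ccc(-n4cnnc4)cc23)CC1` gives 81%.
Compound 3 `CN(Cc1ccsc1)C1CCN(CCCc2c[nH]c3ccc(-n4cnnc4)cc23)CC1` gives 93%.

All three share the same core and differ only in the group attached to a saturated ring carbon. Compound 3 stands highest of the three: the rise a number 12 percentage points higher from compound 2 to compound 3 (beyond the scatter) and the rise a number 20 percentage points higher from compound 1 to compound 3 (beyond the scatter) are both beyond the scatter, while the difference a number 8 percentage points higher from compound 1 to compound 2 (within the scatter) is not.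

Compound 4 `CC(CO)(NC1CCN(CCCc2c[nH]c3ccc(-n4cnnc4)cc23)CC1)c1ccccc1` carries a different group at that same ring carbon: (1-(hydroxymethyl)-1-phenylethyl)amino in place of methyl((thiophen-3-yl)methyl)amino on a saturated ring carbon. For the measured compounds named here, the new group, with its two hydrogen-bond donors, resembles none of the three groups already tried, so no measured step covers this swap directly. The three steps that do bear on it all concern the same position and were all modest or within the scatter, which suggests that this position tolerates change without large swings in maximal response. Since compound 3 already sits at the top of the measured range, a fresh group there is more likely to lose than to gain. A modest drop, a number 13 percentage points lower from compound 3 to compound 4 (beyond the scatter), is therefore expected in this assay, possibly no larger than the scatter. For compound 4 the estimate in this assay is 80%, with a likely range from 60% to 98%.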

Compound 4, largest response reached (reported as efficacy), in percent of the reference or control that the assay uses: 59%
Compound 4: middle estimate off by 21 percentage points, on the high side; the whole stated range lies above it.
By their numbers in this assay, from the lowest: compound 4; then compounds 1 and 2 (each within the scatter of the next); then compound 3.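

The ring carbon is less forgiving than the first three compounds suggested. In this assay, (1-(hydroxymethyl)-1-phenylethyl)amino brings a number 34 percentage points lower from compound 3 to compound 4 (beyond the scatter), a large step, and compound 4 also falls short of the other two compounds, with a number 22 percentage points lower from compound 2 to compound 4 (beyond the scatter) and a number 14 percentage points lower from compound 1 to compound 4 (beyond the scatter), so all three steps lie beyond the scatter and compound 4 has the smallest maximal response of the four. Nothing available here accounts for this loss of maximal response.

The swap changes several things at once: a thiophene ring gives way to a benzene ring, the amine loses its methyl and gains a hydrogen, and a hydroxymethyl group and a further methyl appear, so the compounds shown cannot say which of these changes matters. A (1-phenylethyl)amino group, which lacks only the hydroxymethyl, or a benzyl(methyl)amino group, which differs from compound 3 only in having a benzene ring in place of the thiophene, would begin to separate these changes.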